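A few compounds are considered here, and "the series" means these few. Any claim that something is new, unique, unknown or untested is made for them only; others in the source may bear on it.

Of the compounds shown here, three built on one shared core have been tested in a functional assay on MCF7 cells (Homo sapiens) for antiproliferative activity, read by MTT assay, with a stated time of 48 h; on this read-out lower numbers stand for stronger inhibition and higher numbers for weaker inhibition. Compound 1 `COc1ccc(-c2nc3cccc(-c4cc(OC)c(OC)c(OC)c4)c3o2)cc1F` reaches only a limit of the assay, > 25000 nM. Compound 2 `COc1cc(-c2cccc3nc(-c4cccc(Cl)c4)oc23)cc(OC)c1OC` likewise stands at a limit of the assay, > 25000 nM. Compound 3 `COc1ccc(-c2cccc3nc(-c4ccc5cc[nH]c5c4)oc23)c(OC)c1OC` also gives a limit of the assay, > 25000 nM. The step that the two limits leave unreadable from compound 1 to compound 2 is therefore unreadable, and the whole evidence is the limit of > 25000 nM in this assay, at which 3 of the 3 values shown sit. Compound 4 `COc1cc(-c2cccc3nc(-c4ccco4)oc23)cc(OC)c1OC` differs from compound 2 in one place: furan-2-yl in place of 3-chlorophenyl on an aromatic carbon. Going by the values given here, no measured step reads on a change of this kind, so no step beyond the scatter can be expected in either direction. Compound 4 is estimated at 35000 nM, within 10000 nM to 120000 nM. The step that the limit leaves unreadable from compound 2 to compound 4 is expected to stay within the scatter.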

Compound 4, half-maximal inhibitory concentration: > 25000 nM
Compound 4: only a limit was reported (the forecaster's own chance of this, stated with the estimate: 80%); the middle value does not contradict the limit.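

Going by these compounds alone, the steps from compound 1 and from compound 2 to compound 4 cannot be read, so compound 4 adds no new step. The compounds shown leave open whether any change on the shared core would give a measurable value in this assay: the limit of > 25000 nM in this assay, at which 4 of the 4 values shown sit.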